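A few compounds are considered here, and "the series" means these few. Any claim that something is new, unique, unknown or untested is made for them only; others in the source may bear on it.

Working notes on the series. Compound 1 `CSc1ncnc2c1c(-c1ccccc1)cn2[C@@H]1O[C@H](CO)[C@@H](O)[C@H]1O` and compound 2 `C#Cc1cn([C@@H]2O[C@H](CO)[C@@H](O)[C@H]2O)c2ncnc(NC)c12` share the core; compound 3 `C#Cc1cn([C@@H]2O[C@H](CO)[C@@H](O)[C@H]2O)c2ncnc(SC)c12` puts the methylsulfanyl of compound 1 onto the core of compound 2. In a functional assay on HeLa S3 cells (Homo sapiens) for antiproliferative activity, read by XTT assay, with a stated time of 72 h (a lower number here means a stronger inhibitor, a higher number a weaker inhibitor), compound 1 returns only a limit, > 20000 nM. In this assay compound 2 also returns a limit, > 20000 nM. Compound 2 thus stands at the limit of > 20000 nM in this assay, at which 2 of the 2 values shown sit, with no number of its own. The change to compound 3 is methylsulfanyl in place of methylamino on an aromatic carbon. For the measured compounds named here, no measured step exists between these compounds. The step from compound 2 to compound 3 is expected to be a step that the limit leaves unreadable from compound 2 to compound 3, none beyond the scatter, because compound 1 already gives > 20000 nM with the same group. Compound 3 is therefore estimated at 30000 nM, from 10000 nM to 100000 nM, most probably again a limit.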

Compound 3, half-maximal inhibitory concentration: 110 nM
Compound 3: the middle estimate sits 270-fold (2.44 log units) above what was measured; the whole stated range lies above it.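

In this assay, the group on this aromatic carbon decides the outcome when ethynyl is present: methylsulfanyl in place of methylamino gives an at least 180-fold lower number from compound 2 to compound 3 (2.25 log units; beyond the scatter). Methylsulfanyl alone is not enough: ethynyl in place of phenyl gives an at least 180-fold lower number from compound 1 to compound 3 (2.25 log units; beyond the scatter). Both steps start from a limit, so their full size stays unknown: the limit of > 20000 nM in this assay, at which 2 of the 3 values shown sit.

As far as these compounds go, whether methoxy, ethylsulfanyl or chlorine at this carbon would match methylsulfanyl remains open. So does whether a propynyl group or a nitrile could stand in for ethynyl.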